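Removing the chloro group: an expectation for compound 4

The source may report more compounds than this note shows. Statements on the series, on what has been measured and on what is new or still open speak of the compounds shown alone.

Compound 1 `O[C@@H]1[C@H](O)CS[C@H]1Cn1cnc2c(NCc3cccc(I)c3)nc(Cl)nc21` in an assay on CHO cells for displacement of a labelled ligand from adenosine receptor A3 (Homo sapiens), with a stated time of 60 min, tested at 10 uM (a lower number here means less inhibition, a higher number more inhibition at the concentration tested (going by the name of the read-out)), gives 10%. Compound 2 `O[C@@H]1[C@H](O)CS[C@H]1Cn1cnc2c(NCc3cccc(I)c3)ncnc21` carries hydrogen in place of chloro on an aromatic carbon and in this assay gives 13.9%; the step is a number 3.9 percentage points higher from compound 1 to compound 2 (within the scatter). Compound 3 `O[C@@H]1[C@H](O)CS[C@H]1Cn1cnc2c(NCc3cccc(F)c3)nc(Cl)nc21` differs from compound 1 by fluoro in place of iodo on an aromatic carbon. In this assay compound 3 gives 17.6%, a step of a number 7.6 percentage points higher from compound 1 to compound 3 (within the scatter). Compound 4 `O[C@@H]1[C@H](O)CS[C@H]1Cn1cnc2c(NCc3cccc(F)c3)ncnc21` has not been measured; it differs from compound 3 by hydrogen in place of chloro on an aromatic carbon. This is the same kind of change as that from compound 1 to compound 2, the place differing only in being meta to a (3-fluorobenzyl)amino group rather than meta to a (3-iodobenzyl)amino group. The step from compound 3 to compound 4 is expected to be about a number 2.4 percentage points higher from compound 3 to compound 4 (within the scatter), set beside the earlier a number 3.9 percentage points higher from compound 1 to compound 2 (within the scatter), because the earlier step of a number 3.9 percentage points higher from compound 1 to compound 2 (within the scatter) stayed within the scatter. Compound 4 in this assay is estimated at 20%, between 6% and 34%.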

Compound 4, a percentage reported as inhibition, at one concentration (the size of the read-out at that concentration, not a potency): 8.7%
Compound 4: the middle estimate sits 11.3 percentage points above what was measured; the measured number falls inside the stated range.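

Hydrogen in place of chloro on the core with the (3-fluorobenzyl)amino group gives a number 8.9 percentage points lower from compound 3 to compound 4 (within the scatter) in this assay, and this does not differ from the same change on the core of compound 1: the same change on two cores in this assay, a number 3.9 percentage points higher (within the scatter) from compound 1 to compound 2 and a number 8.9 percentage points lower (within the scatter) from compound 3 to compound 4, 12.8 percentage points apart, within the scatter of two such steps. Fluoro in place of iodo, read on the compounds without chloro, gives a number 5.2 percentage points lower from compound 2 to compound 4 (within the scatter), and again no difference between the cores shows: the same change on two cores in this assay, a number 7.6 percentage points higher (within the scatter) from compound 1 to compound 3 and a number 5.2 percentage points lower (within the scatter) from compound 2 to compound 4, 12.8 percentage points apart, within the scatter of two such steps. Every step here lies within the scatter, so the data show that neither change depends on the core only in the limited sense that no dependence can be seen, and they do not show that either change has a real effect of its own or carries over with a fixed size or direction.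

Open, as far as these compounds go, is what an amine or a methyl group would give in place of the chloro group, and what a bromo or a methoxy group would give in place of the iodo group. A read-out at a single concentration also leaves the potency of these compounds open.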